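This account rests on a few compounds, and the source may have more. Where it says the series, first, only, none or still open, it means among the compounds named here.

Working notes on the carbonyl substituent in this series.

The shared core is held fixed across the compounds; they differ only in the group on a carbonyl carbon whose other neighbour is an amide-type nitrogen in a ring. Compound 1 `CCOC(=O)N1CCCc2cc(S(=O)(=O)N3CC(c4ccccc4)NC3=O)ccc21` carries an ethoxy there and in a functional assay on A549 cells (Homo sapiens) for antiproliferative activity, read by MTT assay (on this read-out higher numbers stand for weaker inhibition and lower numbers for stronger inhibition), compound 1 gives 344 nM. Compound 3 `O=C(c1ccccc1)N1CCCc2cc(S(=O)(=O)N3CC(c4ccccc4)NC3=O)ccc21` carries a phenyl at that carbon; in this assay compound 3 gives 8140 nM. Compound 2 `O=C(CCl)N1CCCc2cc(S(=O)(=O)N3CC(c4ccccc4)NC3=O)ccc21` has no result: in this assay compound 2 is reported as "not determined" (no result reported). Of the two numbers available, compound 1 stands lowest, and the single step shown, a 24-fold higher number from compound 1 to compound 3 (1.37 log units; beyond the scatter), is large and runs towards the higher number.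

Compound 4 `NC(=O)N1CCCc2cc(S(=O)(=O)N3CC(c4ccccc4)NC3=O)ccc21` is the next member: amino in place of ethoxy on a carbonyl carbon. Within the data shown here, the only measured change at this carbon, a 24-fold higher number from compound 1 to compound 3 (1.37 log units; beyond the scatter), replaces ethoxy by a larger group, whereas compound 4 moves to a smaller group that brings a hydrogen-bond donor and drops an acceptor, so that step is a loose guide at best; it shows the position is sensitive but gives no direction for amino. A modest move to a higher number is therefore expected for compound 4, a 2.3-fold higher number from compound 1 to compound 4 (0.37 log units; beyond the scatter). Compound 4 is expected to give 800 nM in this assay, within 200 nM to 4000 nM.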

Compound 4, half-maximal inhibitory concentration: 2540 nM
Compound 4: the middle estimate sits 3.2-fold (0.50 log units) below what was measured, and the stated range covers the measured number.
By their numbers in this assay, from the lowest: compound 1; then compound 4; then compound 3.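

Against ethoxy on this carbonyl carbon, amino is a second replacement that moves to a higher number in this assay (a 7.4-fold higher number from compound 1 to compound 4 (0.87 log units; beyond the scatter)), so the earlier sensitivity no longer rests on phenyl alone. The amino member also separates from the phenyl member (a 3.2-fold lower number from compound 3 to compound 4 (0.51 log units; beyond the scatter)), which shows that the read-out at this carbon depends on which group is present and gives an order of ethoxy, amino, then phenyl across compound 1, compound 4 and compound 3, with none of the three going against it. This order describes the three listed groups only, and nothing available accounts for it.

Steps to compound 2 cannot be read, so the place of its chloromethyl group in this order remains unknown. From the compounds shown here alone, it also remains open whether the low number of compound 1 is particular to ethoxy or extends to methoxy or a longer chain such as butoxy on the same carbon, and whether methylamino or dimethylamino would stay near compound 4.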